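This account rests on a few compounds, and the source may have more. Where it says the series, first, only, none or still open, it means among the compounds named here.

Compound 1 `O=S(=O)(c1ccccc1)c1c(OCCCCCCO)no[n+]1[O-]` — in a functional assay on KG-1 cells (Homo sapiens) for inhibition, read by MTT assay, with a stated time of 48 h (a higher number here means a weaker inhibitor, a lower number a stronger inhibitor), compound 1 gives "not determined" (no result reported)
Compound 2 `O=C(CCCCOc1no[n+]([O-])c1S(=O)(=O)c1ccccc1)NO` — in this assay compound 2 gives 1910 nM

Compound 1 thus stands nowhere on the numbers: it has no result in this assay, so it offers no anchor of its own. Among the measured compounds shown here, the one measured point is compound 2, which in this assay gives 1910 nM. The step to compound 3 `O=C(NO)OCCOCCOc1no[n+]([O-])c1S(=O)(=O)c1ccccc1` changes compound 1 in one place: 2-((hydroxycarbamoyl)oxy)ethoxy in place of 4-hydroxybutyl on a saturated chain carbon, two bonds along the chain from an oxygen on an aromatic ring. For the measured compounds named here, no measured pair shows what this change does, so the size of the step in this assay cannot be drawn from the data; the account can only lean on what compound 2 shows, as the nearest measured structure with a comparable chain ending. On that basis the author expects compound 3 to land in the same region as compound 2, with no direction beyond the scatter claimed. Compound 3 is estimated at 2500 nM, with a range of 700 nM to 9000 nM.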

Compound 3, half-maximal inhibitory concentration: 5380 nM
Beside the measured number, compound 3's estimate is 2.2-fold (0.33 log units) below it, and the stated range covers the measured number.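

In this assay this position, on a saturated chain carbon two bonds along the chain from an oxygen on an aromatic ring, now has its first readable step: 2-((hydroxycarbamoyl)oxy)ethoxy in place of 2-(hydroxycarbamoyl)ethyl gives a 2.8-fold higher number from compound 2 to compound 3 (0.45 log units; beyond the scatter). The change makes the compound a weaker inhibitor, but only modestly, so the number at this position does respond to how the chain is built, and activity in the same cells is kept with the longer group. Nothing available explains the shift.

Compound 1 offers no number, so the steps that start from its 4-hydroxybutyl group cannot be read. On these data alone, how a carboxylic acid or an amine at the end of the chain would compare with these two chain endings stays open.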